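This account rests on a few compounds, and the source may have more. Where it says the series, first, only, none or still open, it means among the compounds named here.

Three dithioacetal diacids have been characterised in an assay on membranes from lung (Cavia porcellus) for binding affinity to cysteinyl leukotriene receptor (Homo sapiens); a higher number here means a weaker inhibitor, a lower number a stronger inhibitor. Compound 1 `CCCCCCCCCCCCc1ccccc1C(SCCC(=O)O)SCCC(=O)O` gives 445 nM. Compound 2 `CCCCCCCCCCCCCCc1ccccc1C(SCCC(=O)O)SCCC(=O)O`, which carries a longer chain on the same core, gives 1250 nM. Compound 3 `CCCCCCCCCCCCCOc1cccc(C(SCCC(=O)O)SCCC(=O)O)c1`, built on a different core, gives 530 nM; how the cores of compound 3 and compound 2 differ is not broken down here. The numbers for compound 3 and compound 1 lie within the scatter of each other, so nothing is said about their order.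

For the measured compounds named here, the one counted step among the measured compounds is the shortening of the chain: hydrogen in place of ethyl on a saturated chain carbon, ten or more bonds along the chain from an aromatic carbon. That change gave a 2.8-fold lower number from compound 2 to compound 1 (0.45 log units; beyond the scatter).

Compound 4 `CCCCCCCCCCCOc1cccc(C(SCCC(=O)O)SCCC(=O)O)c1` has not yet been measured. It stands to compound 3 as compound 1 stands to compound 2: hydrogen in place of ethyl on a saturated chain carbon, ten or more bonds along the chain from an oxygen on an aromatic ring. The surroundings of the place are not identical, since in one case the chain is counted from an aromatic carbon and in the other from an oxygen on an aromatic ring, so this is the same kind of change rather than the same change.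

The expectation for compound 4 rests on a single example, the step from compound 2 to compound 1, because a 2.8-fold lower number from compound 2 to compound 1 (0.45 log units; beyond the scatter) was modest but beyond the scatter. Compound 4 is therefore expected to show a step of a 2.4-fold lower number from compound 3 to compound 4 (0.38 log units; beyond the scatter) in this assay, on the cautious assumption that the effect carries over across the two cores. On that basis the value for compound 4 in this assay is estimated at 220 nM, with a plausible range from 100 nM to 500 nM.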

Compound 4, inhibition constant: 78 nM
The estimate for compound 4 lay 2.8-fold (0.45 log units) above the measured number, outside the stated range (below it).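

In this assay, the shortening of the chain on the core of compound 3 gave a 6.8-fold lower number from compound 3 to compound 4 (0.83 log units; beyond the scatter), and beside the earlier step on the other core the two agree in direction and cannot be told apart in size: the same change on two cores in this assay, a 2.8-fold lower number (0.45 log units; beyond the scatter) from compound 2 to compound 1 and a 6.8-fold lower number (0.83 log units; beyond the scatter) from compound 3 to compound 4, 2.4-fold (0.38 log units) apart, within the scatter of two such steps Replacing ethyl with hydrogen at this far end of the chain therefore lowered the number on both cores, so in these two pairs the change carried from one core to the other, and the larger figure on the core of compound 3 is no firm sign of a larger effect there. For the compounds shown here, this rests on only two pairs, however, and it shows neither that the change would carry to a further core nor why the shorter chain gives the lower number.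

The compounds shown leave open how the number moves along a fuller run of chain lengths on either core, including a still shorter chain, and whether it keeps falling or passes through a lowest point. They also leave open whether the same step would hold on a chain ending in a hydroxyl group or a phenyl ring, or with an amide in place of one of the carboxylic acids.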